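Removing one aryl methyl from compound 1: metabolic stability

The source may report more compounds than this note shows. Statements on the series, on what has been measured and on what is new or still open speak of the compounds shown alone.

Compound 1 `COc1ccc2nc(C)cc(OCC(=O)Nc3cc(C)cc(C)c3)c2c1` is measured in an ADME assay on microsomes from liver (Mus musculus) for metabolic stability, read by LC-MS, using NADPH, with a stated time of 30 min, tested at 0.5 uM; on this read-out higher numbers stand for a longer-lived compound and lower numbers for a shorter-lived compound. Its value there is a limit of the assay: compound 1 gives < 0.0834 h. Two close analogues share the same core. Compound 2 `Cc1cc(C)cc(NC(=O)COc2cc(C)nc3ccc(C)cc23)c1` carries methyl in place of methoxy on an aromatic carbon; its result is likewise a limit, compound 2 giving < 0.0834 h. Compound 3 `COc1ccc2nc(C)cc(OCCNc3cc(C)cc(C)c3)c2c1` lacks the amide carbonyl; its result is also a limit, compound 3 giving < 0.0834 h. Among the measured compounds shown here, the only single-change step among them, a step that the two limits leave unreadable from compound 1 to compound 2, cannot be sized, because of the limit of < 0.0834 h in this assay, at which 3 of the 3 values shown sit. Compound 4 `COc1ccc2nc(C)cc(OCC(=O)Nc3cccc(C)c3)c2c1` differs from compound 1 by hydrogen in place of methyl on an aromatic carbon. No measured step bears on this change, and all shown values sit at the limit, so the starting point itself is unreadable. The expectation for compound 4 is therefore that this assay returns a limit again, with a step that the limit leaves unreadable from compound 1 to compound 4 taken as no step beyond the scatter; the estimated half-life of compound 4 is 0.06 h, within 0.02 h to 0.15 h.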

Compound 4, half-life: < 0.0834 h
Compound 4: no number, only a limit; the forecaster's own chance of this, stated with the estimate: 80%; the middle value is on the limit's open side.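

No step from compound 1 to compound 4 can be read in this assay, because both results are limits: the limit of < 0.0834 h in this assay, at which 4 of the 4 values shown sit.

The compounds shown leave open what the actual half-life of each compound is, and whether hydrogen in place of methyl changes it at all.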